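Swapping a furan for a tolyl group on the pyrazoline ring

The source may hold more compounds than are shown below. What is called first, only, known or untested is meant among the compounds shown, and "the series" means these compounds.

Measured so far:
compound 1 `Cc1ccc(C2CC(c3ccccc3)=NN2C(=O)COc2ccc(/C=C3/SC(=O)NC3=O)cc2)cc1`: 1200 nM
compound 2 `O=C1NC(=O)/C(=C\c2ccc(OCC(=O)N3N=C(c4ccc(F)cc4F)CC3c3ccco3)cc2)S1`: 15000 nM

Both compounds share a common core and were tested in an assay on cells for inhibition of histone deacetylase 4 (Homo sapiens), read by fluorescence, with a stated time of 30 min; on this read-out higher numbers stand for weaker inhibition and lower numbers for stronger inhibition. Compound 1 gives 1200 nM, whereas compound 2 gives 15000 nM, the higher of the two numbers; the gap between them lies beyond the usual scatter, so compound 2 is the weaker inhibitor of the pair. The two differ in two places at once, so no single change can be read from their values alone.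

Compound 3 `Cc1ccc(C2CC(c3ccc(F)cc3F)=NN2C(=O)COc2ccc(/C=C3/SC(=O)NC3=O)cc2)cc1` has not yet been measured. It is compound 2 with 4-methylphenyl in place of furan-2-yl on a saturated ring carbon. The 2,4-difluorophenyl group of compound 2 is kept, so compound 3 sits between the two measured compounds in structure. Since compound 3 shares the 4-methylphenyl group with compound 1, which gives 1200 nM, the number is expected to fall, though not necessarily all the way. The expected step is a 4.3-fold lower number from compound 2 to compound 3 (0.63 log units; beyond the scatter), a drop beyond the scatter. Compound 3 is estimated at 3500 nM, within a range from 1000 nM to 12000 nM.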

Compound 3, half-maximal inhibitory concentration: 1500 nM
Compound 3: the middle estimate sits 2.3-fold (0.37 log units) above what was measured; the range from low to high includes it.
By their numbers in this assay, from the lowest: compounds 1 and 3 (each within the scatter of the next); then compound 2.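

With the 2,4-difluorophenyl group held fixed, 4-methylphenyl in place of furan-2-yl on the saturated ring carbon gives a 10-fold lower number from compound 2 to compound 3 (1.00 log units; beyond the scatter) in this assay, so a change at this one position clearly moves the number. This could not be read from compound 1 and compound 2, which differ in two places at once. With 4-methylphenyl held fixed, 2,4-difluorophenyl in place of phenyl on the carbon with a double bond to nitrogen gives a 1.3-fold higher number from compound 1 to compound 3 (0.10 log units; within the scatter), so compound 1 and compound 3 cannot be told apart, and the gap between compound 1 and compound 2 traces to the saturated ring carbon, though no measurement shown gives a reason for the step there.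

Furan-2-yl and 4-methylphenyl differ in ring size, ring oxygen and methyl group all at once, so it remains open which of these matters; a plain phenyl or a 4-methoxyphenyl at this carbon would help separate them. From the compounds shown here alone, it is also open whether the fluorine atoms would matter with furan-2-yl on the saturated ring carbon, since their swap can be read only alongside 4-methylphenyl.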